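A few compounds are considered here, and "the series" means these few. Any claim that something is new, unique, unknown or untested is made for them only; others in the source may bear on it.

In a functional assay on MIA PaCa-2 cells (Homo sapiens) for inhibition, read by MTT assay, with a stated time of 24 h (on this read-out lower numbers stand for stronger inhibition of growth and higher numbers for weaker inhibition of growth), compound 3 `N[C@@H](CC(=O)O[C@H]1C[C@H](n2cc(F)c(=O)[nH]c2=O)O[C@@H]1CO)C(=O)O` gives 4100000 nM, which lies within the scatter of both compound 2 `N[C@@H](CCC(=O)O[C@H]1C[C@H](n2cc(F)c(=O)[nH]c2=O)O[C@@H]1CO)C(=O)O` at 2500000 nM and compound 1 `CC(C)[C@H](N)C(=O)OC[C@H]1O[C@@H](n2cc(F)c(=O)[nH]c2=O)C[C@@H]1OC(=O)[C@@H](N)C(C)C` at 2400000 nM. Compound 4 `CC(C)[C@H](N)C(=O)O[C@H]1C[C@H](n2cc(F)c(=O)[nH]c2=O)O[C@@H]1CO` carries 1-amino-2-methylpropyl in place of 2-amino-2-carboxyethyl on a carbonyl carbon. Within the data shown here, the one measured step that alters this group, a 1.6-fold higher number from compound 2 to compound 3 (0.21 log units; within the scatter), stays within the scatter. Compound 1, which also carries 1-amino-2-methylpropyl, gives 2400000 nM, again within the scatter of compound 3. No change beyond the scatter is therefore expected in this assay, and the expected size is a 1.4-fold lower number from compound 3 to compound 4 (0.14 log units; within the scatter). For compound 4 the estimated value is 3000000 nM, with an expected range from 1500000 nM to 6000000 nM.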

Compound 4, concentration for 50% growth inhibition: 2600000 nM
Compound 4: the middle estimate sits 1.2-fold (0.06 log units) above what was measured, and the stated range covers the measured number.
By their numbers in this assay, from the lowest: compounds 1, 2, 4 and 3 (each within the scatter of the next).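

In this assay, 1-amino-2-methylpropyl in place of 2-amino-2-carboxyethyl on a carbonyl carbon stays within the scatter (a 1.6-fold lower number from compound 3 to compound 4 (0.20 log units; within the scatter)), and the same group in place of 3-amino-3-carboxypropyl does too (a 1.0-fold higher number from compound 2 to compound 4 (0.02 log units; within the scatter)). Hydrogen in place of (1-amino-2-methylpropyl)carbonyl on an oxygen on a saturated carbon also stays within the scatter (a 1.1-fold higher number from compound 1 to compound 4 (0.03 log units; within the scatter)). No supporting measurement explains these results. Going by these compounds, whether a longer chain, or a carboxylic acid without the amine, on this carbonyl carbon would stay within the scatter remains open.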